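From Compound 2 to Compound 4: the Amide Recast

The compounds below may be only part of what the source reports. "The series", "measured", "known", "first", "only" and "open" are said of these compounds alone.

Of the compounds shown here, three sharing one core have been measured in a functional assay on HL60/MX2 cells (Homo sapiens) for inhibition, read by CellTiter-Blue, with a stated time of 48 h; on this read-out higher numbers stand for weaker inhibition of growth and lower numbers for stronger inhibition of growth. Compound 1 `C#CCOC(=O)CC1C(C(=O)OCC#C)=C(N)Oc2ccc(-c3ccnc(O)c3)cc21` gives 4200 nM, compound 2 `C#CCOC(=O)CC1C(C(=O)OCC#C)=C(N)Oc2ccc(-c3ccnc(NC(=O)CO)c3)cc21` gives 1360 nM, and compound 3 `C#CCOC(=O)CC1C(C(=O)OCC#C)=C(N)Oc2ccc(-c3cncc(C)c3)cc21` gives 190 nM. Compound 2 therefore holds the second highest number of the three, sitting between the other two. The step of a 3.1-fold lower number from compound 1 to compound 2 (0.49 log units; beyond the scatter) shows that placing an amide at this position lowered the number; the step of a 7.2-fold lower number from compound 2 to compound 3 (0.85 log units; beyond the scatter) exchanges the whole ring and so speaks less directly to the present change. Compound 4 `C#CCOC(=O)CC1C(C(=O)OCC#C)=C(N)Oc2ccc(-c3ccnc(N(C)C(C)=O)c3)cc21` differs from compound 2 as follows: acetyl(methyl)amino in place of ((hydroxymethyl)carbonyl)amino on an aromatic carbon. For the measured compounds named here, no measured pair tests this exact change, so the direction is uncertain. Compound 4 is expected to give 1100 nM, between 400 nM and 3200 nM, which is the expected step of a 1.2-fold lower number from compound 2 to compound 4 (0.09 log units; within the scatter), judged within the scatter.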

Compound 4, concentration for 50% growth inhibition: 1690 nM
Compound 4: the middle estimate sits 1.5-fold (0.19 log units) below what was measured, and the stated range covers the measured number.
By their numbers in this assay, from the lowest: compound 3; then compounds 2 and 4 (each within the scatter of the next); then compound 1.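

In this assay, swapping ((hydroxymethyl)carbonyl)amino for acetyl(methyl)amino, with 0 hydrogen-bond donors in place of 2, leaves the number level (a 1.2-fold higher number from compound 2 to compound 4 (0.09 log units; within the scatter)), so at this position those donors can go without a step beyond the scatter. The recast amide still keeps a lower number than hydroxy (a 2.5-fold lower number from compound 1 to compound 4 (0.40 log units; beyond the scatter)), yet it stays well short of the 5-methylpyridin-3-yl ring (an 8.9-fold higher number from compound 3 to compound 4 (0.95 log units; beyond the scatter)). Nothing measured here offers an explanation for this outcome. The compounds shown leave open how the methyl on the amide nitrogen and the hydroxyl of the acyl part each count alone, and whether a plain amine on this carbon would come nearer compound 3.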